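Aryl ether swap on the shared core: compound 3 to compound 4

This account rests on a few compounds, and the source may have more. Where it says the series, first, only, none or still open, it means among the compounds named here.

Readings in a functional assay on HepG2 cells (Homo sapiens) for antiproliferative activity, read by MTT assay, with a stated time of 72 h; a higher number here means a weaker inhibitor, a lower number a stronger inhibitor:
- compound 1, `Cc1nn(C)c(Oc2cccc(F)c2)c1/C=N\CCCCCOc1cc2oc(=O)cc(C)c2cc1Cl`: 13400 nM
- compound 2, `Cc1ccc(Oc2c(/C=N\CCCCCOc3cc4oc(=O)cc(C)c4cc3Cl)c(C)nn2C)cc1`: 10300 nM
- compound 3, `Cc1nn(C)c(Oc2ccc(F)cc2F)c1/C=N\CCCCCCOc1cc2oc(=O)cc(C)c2cc1Cl`: > 25000 nM

Compound 3 gives only a limit in this assay, (the limit of > 25000 nM in this assay, at which 1 of the 3 values shown sits); no number is available for it. Compounds 1 and 2, which carry a different linker from compound 3, sit close together: a 1.3-fold lower number from compound 1 to compound 2 (0.11 log units; within the scatter). Among the compounds with values here, that is the only measured step in the set, and it concerns a change of the aryl group on the same oxygen as the change now considered.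

Compound 4, `Cc1nn(C)c(Oc2ccc(Br)cc2)c1/C=N\CCCCCCOc1cc2oc(=O)cc(C)c2cc1Cl`, differs from compound 3 by 4-bromophenyl in place of 2,4-difluorophenyl on an oxygen on an aromatic ring. Within the data shown here, the one step that bears on this kind of swap, the step from compound 1 to compound 2, was within the scatter, so no shift beyond the scatter is expected here; the starting point is itself only a limit, so a limit is the most likely outcome for compound 4 as well. The expected step is a number no higher from compound 3 to compound 4 (the limit leaves the size open). Compound 4 is expected at about 25000 nM, in the range 8000 nM to 60000 nM.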

Compound 4, half-maximal inhibitory concentration: 4630 nM
Compound 4: the middle estimate sits 5.4-fold (0.73 log units) above what was measured; measured number outside the range, below it.
By their numbers in this assay, from the lowest: compound 4; then compounds 2 and 1 (each within the scatter of the next). At a limit, above all of these: compound 3.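

In this assay, the group on this oxygen can shift the number beyond the scatter: an at least 5.3-fold lower number from compound 3 to compound 4 (0.73 log units; beyond the scatter). Within the data shown here, the only earlier step of this kind, a 1.3-fold lower number from compound 1 to compound 2 (0.11 log units; within the scatter), stayed within the scatter, so the compounds before compound 4 gave no sign that this position responds to a change of aryl group. The new step gives only a minimum size, with compound 3 held at a limit of the assay: the limit of > 25000 nM in this assay, at which 1 of the 4 values shown sits.

As far as these compounds go, whether the step follows the bromine or the loss of the two fluorines stays open, as does whether a 4-chlorophenyl or an unsubstituted phenyl on this oxygen would read like compound 4 or like compound 3. Also open is what the linker contributes, as no pair shown differs in the linker alone.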